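The source may hold more compounds than are shown below. What is called first, only, known or untested is meant among the compounds shown, and "the series" means these compounds.

Measured so far in an assay on isolated protein for inhibition of G protein-coupled receptor kinase 5 (Homo sapiens), read by TR-FRET, with stated times of 10 min and 1 h; on this read-out lower numbers stand for stronger inhibition and higher numbers for weaker inhibition:
compound 1 `Nc1ncc(-c2cnn(C3CCNCC3)c2)cc1-c1nc2ccc(Oc3ccccc3)cc2o1` gives 4000 nM
compound 2 `Nc1ncc(-c2cnn(C3CCNCC3)c2)cc1-c1nc2ccc(-c3ccc4[nH]ncc4c3)cc2o1` gives 1140 nM
compound 3 `Nc1ncc(-c2cnn(C3CCNCC3)c2)cc1-c1nc2ccc(NC(=O)Nc3ccccc3)cc2o1` gives 1660 nM

All three share the same core and differ only in the group on the aromatic carbon of the fused ring. Compound 3 stands second highest of the three numbers: a 2.4-fold lower number from compound 1 to compound 3 (0.38 log units; beyond the scatter) and a 1.5-fold higher number from compound 2 to compound 3 (0.16 log units; within the scatter), so compound 3 and compound 2 cannot be separated, while compound 1 lies apart from both. The other step, a 3.5-fold lower number from compound 1 to compound 2 (0.55 log units; beyond the scatter), is likewise modest.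

Compound 4 `Nc1ncc(-c2cnn(C3CCNCC3)c2)cc1-c1nc2ccc(NC(=O)c3ccccc3)cc2o1` differs from compound 3 by phenyl in place of anilino on a carbonyl carbon. Within the data shown here, no measured step bears directly on this change; the steps seen concern the exchange of the whole group on the aromatic carbon, and all stayed within a modest span. With the ring and carbonyl retained, a step no larger than the scatter is therefore expected, with no direction favoured, giving a 1.1-fold lower number from compound 3 to compound 4 (0.04 log units; within the scatter) as the expected change. For compound 4 in this assay the estimate is 1500 nM, with a range of 600 nM to 4000 nM.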

Compound 4, half-maximal inhibitory concentration: 3490 nM
Estimate against measurement, compound 4: 2.3-fold (0.37 log units) below; low and high end bracket the measured number.
By their numbers in this assay, from the lowest: compounds 2 and 3 (each within the scatter of the next); then compounds 4 and 1 (each within the scatter of the next).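

In this assay, among these compounds, phenyl in place of anilino on a carbonyl carbon gives a 2.1-fold higher number from compound 3 to compound 4 (0.32 log units; beyond the scatter), so a change within the group, taking out only the anilino nitrogen and its hydrogen, moves the number beyond the scatter, whereas the earlier steps exchanged the whole group. With benzamido at this position, the comparisons with the other groups read a 3.1-fold higher number from compound 2 to compound 4 (0.49 log units; beyond the scatter) and a 1.1-fold lower number from compound 1 to compound 4 (0.06 log units; within the scatter), leaving benzamido inseparable from phenoxy, while (phenylcarbamoyl)amino and 1H-indazol-5-yl both lie apart from it. No supporting data are available to account for the step from anilino to phenyl.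

As far as these compounds go, whether the nitrogen or its hydrogen matters remains open, and an N-methylanilino group or a benzyl group on the carbonyl carbon would separate the two. Also open, from the compounds shown here alone, is how the anilino ring itself tolerates a fluorine, a methoxy group or an amine.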